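A few compounds are considered here, and "the series" means these few. Any claim that something is new, unique, unknown or untested is made for them only; others in the source may bear on it.

Among the compounds with values here, compound 1 `COC[C@H](NC1CCN(CCCc2c[nH]c3ccc(-n4cnnc4)cc23)CC1)c1ccccc1` is one of three compounds measured in a functional assay on CHO cells for activation of 5-hydroxytryptamine receptor 1D (Homo sapiens), read by GTPgammaS binding (a lower number here means a smaller maximal response, a higher number a larger maximal response), and compound 1 reaches 93%. Compound 2 `CC(=O)Nc1ccc([C@H](C)NCC2CCN(CCCc3c[nH]c4ccc(-n5cnnc5)cc34)CC2)cc1` gives 99%, which sits within the usual scatter of the number for compound 1, so the two cannot be ordered. Within the data shown here, compound 3 `NC(=O)OC[C@H](NC1CCN(CCCc2c[nH]c3ccc(-n4cnnc4)cc23)CC1)c1ccccc1` gives 73%, and the only single-point step among the measured compounds is a number 20 percentage points lower from compound 1 to compound 3 (beyond the scatter), where a carbamoyl takes the place of a methyl on an oxygen on a saturated carbon. Compound 1 therefore stands second highest of the three, indistinguishable from compound 2 and clearly above compound 3.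

Compound 4 `CN(Cc1ccccc1)CC1CCN(CCCc2c[nH]c3ccc(-n4cnnc4)cc23)CC1` differs from compound 1 by (benzyl(methyl)amino)methyl in place of (2-methoxy-1-phenylethyl)amino on a saturated ring carbon. Among the measured compounds shown here, the one measured step concerns a different part of the molecule, the oxygen-bearing side chain, and says little about the amine that is changed here; compound 2, with a (1-(4-acetamidophenyl)ethyl)amino group, shows only that a different substituent on this side of the core keeps the response high. All three measured compounds keep the hydrogen-bond donor at this amine, and compound 4 does not. For the measured compounds named here, with no direct precedent, a modest drop or none beyond the scatter seems the expected outcome, so the step from compound 1 to compound 4 is estimated as a number 13 percentage points lower from compound 1 to compound 4 (beyond the scatter). Compound 4 is accordingly expected to give about 80% in this assay, with a plausible range from 55% to 100%.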

Compound 4, largest response reached (reported as efficacy), in percent of the reference or control that the assay uses: 93%
Compound 4: the middle estimate sits 13 percentage points below what was measured; measured number inside the range.
By their numbers in this assay, from the lowest: compound 3; then compounds 1, 4 and 2 (each within the scatter of the next).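

In this assay, the step at this saturated ring carbon is no change at the digits printed from compound 1 to compound 4 (within the scatter), even though (benzyl(methyl)amino)methyl replaces the whole of (2-methoxy-1-phenylethyl)amino. The group that leaves carries a hydrogen-bond donor, an oxygen and a defined stereocentre, while the group that enters has no hydrogen-bond donor, no oxygen and no defined stereocentre, so this pair shows that the maximal response can be kept without any of those three features. This contrasts with the smaller edit on the side chain, where a number 20 percentage points lower from compound 1 to compound 3 (beyond the scatter) is beyond the scatter, and so a change in this group need not cost response, although a single pair cannot show how each feature would act alone. Nothing measured here explains why the response holds.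

Every compound shown keeps a six-membered aromatic ring of carbon only in this group, so it remains open whether a simple dimethylaminomethyl or a carboxylic acid on the same ring carbon would keep the response. Maximal response also leaves open how much of each compound is needed to reach it.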